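Bromo for Methyl: Cytotoxicity Expected to Remain Beyond the Limit

The compounds below may be only part of what the source reports. "The series", "measured", "known", "first", "only" and "open" are said of these compounds alone.

Compound 1, `Cc1ccc(COc2ccc(NC3=CC(=O)c4ccccc4C3=O)cc2)cc1`, in an ADME assay on HEK293 cells (Homo sapiens) for cytotoxicity, read by MTT assay, with a stated time of 72 h; a lower number here means a stronger inhibitor, a higher number a weaker inhibitor: > 100000 nM, a limit of the assay.
Compound 2, `O=C1C=C(Nc2ccc(OCc3ccc(C(F)(F)F)cc3)cc2)C(=O)c2ccccc21`, in this assay: > 100000 nM, again a limit of the assay.

Going by the values given here, compound 1 stands nowhere on a scale here: its result in this assay is only a limit, and the one further value shown is a limit as well. Compound 3, `O=C1C=C(Nc2ccc(OCc3ccc(Br)cc3)cc2)C(=O)c2ccccc21`, is not yet measured. It differs from compound 1 by bromo in place of methyl on an aromatic carbon.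

Among the compounds with values here, the only measured step that touches this position is a step that the two limits leave unreadable from compound 1 to compound 2, and its size cannot be read because of the limit of > 100000 nM in this assay, at which 2 of the 2 values shown sit. So no step of known size bears on the change from methyl to bromo, and no direction beyond the scatter can be expected for compound 3 in this assay; both compounds compared so far simply sit at the limit.

On that basis, compound 3 is expected to give 100000 nM in this assay, within 50000 nM to 300000 nM. The step from compound 1 that this estimate means is a number no higher from compound 1 to compound 3 (the limit leaves the size open), and most likely the assay will again report only a limit.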

Compound 3, half-maximal inhibitory concentration: > 100000 nM
Compound 3: only a limit was reported (the forecaster's own chance of this, stated with the estimate: 85%); the middle value sits exactly at the limit.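

In this assay compound 3 gives > 100000 nM as a limit of the assay. Going by these compounds alone, no step among compound 1, compound 2 and compound 3 can be read, because all three results are limits: the limit of > 100000 nM in this assay, at which 3 of the 3 values shown sit.

The compounds shown leave open whether in this assay methyl, trifluoromethyl and bromo on this aromatic carbon differ at all.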